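The source may hold more compounds than are shown below. What is called first, only, known or untested is meant among the compounds shown, and "the series" means these compounds.

In a functional assay on NCI-H460 cells (Homo sapiens) for inhibition, read by MTT assay, with a stated time of 72 h (a lower number here means a stronger inhibitor, a higher number a weaker inhibitor), compound 1 `COc1cc2c(Oc3ccc(NC(=O)c4nn(-c5ccccc5)c(=O)cc4C)cc3F)ccnc2cc1OCCCN1CCCCC1` gives 280 nM, compound 2 `COc1cc2c(Oc3ccc(NC(=O)c4nn(-c5cccc(F)c5)c(=O)cc4C)cc3F)ccnc2cc1OCCCN1CCCCC1` gives 360 nM, and compound 3 `COc1cc2c(Oc3ccc(NC(=O)c4nn(-c5ccc(Cl)cc5)c(=O)cc4C)cc3F)ccnc2cc1OCCCN1CCCCC1` gives 460 nM, the highest of the three numbers, though compound 2 and compound 1 both lie within the scatter of it. Compound 4 `COc1cc2c(Oc3ccc(NC(=O)c4nn(-c5ccc(Cl)cc5Cl)c(=O)cc4C)cc3F)ccnc2cc1OCCCN1CCCCC1` differs from compound 3 by chloro in place of hydrogen on an aromatic carbon. Going by the values given here, two measured steps bear on adding a halogen to this ring: a 1.6-fold higher number from compound 1 to compound 3 (0.22 log units; within the scatter) and a 1.3-fold higher number from compound 1 to compound 2 (0.11 log units; within the scatter). Both stayed within the scatter, so a second chloro is expected to shift this assay little, if at all, perhaps slightly toward a higher number. The step expected here is a 1.2-fold higher number from compound 3 to compound 4 (0.08 log units; within the scatter). Compound 4 is estimated at 550 nM, with a range from 250 nM to 1200 nM.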

Compound 4, half-maximal inhibitory concentration: 390 nM
Estimate against measurement, compound 4: 1.4-fold (0.15 log units) above; the measured number falls inside the stated range.
By their numbers in this assay, from the lowest: compounds 1, 2, 4 and 3 (each within the scatter of the next).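

In this assay, a second chloro, placed ortho to a large group on the ring, leaves the number within the scatter (a 1.2-fold lower number from compound 3 to compound 4 (0.07 log units; within the scatter)). The 2,4-dichlorophenyl group also stays within the scatter of the two simpler rings, with a 1.1-fold higher number from compound 2 to compound 4 (0.03 log units; within the scatter) and a 1.4-fold higher number from compound 1 to compound 4 (0.14 log units; within the scatter), so this ring accepts two chloro groups with no readable change in this assay. Nothing available accounts for this result.

The compounds shown carry only halogens on this ring, so an amine or a carboxylic acid there remains open. Also open, going by these compounds, is how a chloro at this new position would behave alone.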